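Piperazine for methoxy on a phenyl-substituted bicyclic core

A few compounds are considered here, and "the series" means these few. Any claim that something is new, unique, unknown or untested is made for them only; others in the source may bear on it.

Measured compounds:
compound 1, `COc1ccc(-c2cc3[nH]nc(N)c3c(=O)[nH]2)cc1`, 59%
compound 2, `CN1CCN(c2ccc(-c3cc4[nH]nc(N)c4c(=O)[nH]3)cc2)CC1`, 55%
compound 3, `COc1ccc(-c2cc3nn(-c4ccccc4)c(N)c3c(=O)[nH]2)cc1`, 7%

In an assay on isolated protein for inhibition of MAP kinase-activated protein kinase 2 (Homo sapiens), read by mobility shift assay, tested at 30 uM (on this read-out higher numbers stand for more inhibition at the one concentration tested (going by the name of the read-out) and lower numbers for less inhibition), compound 1 gives 59% and compound 2 gives 55%. The two share a core and differ by 4-methylpiperazin-1-yl in place of methoxy on an aromatic carbon; the step of a number 4 percentage points lower from compound 1 to compound 2 (within the scatter) is within the scatter, so the two values cannot be told apart. Compound 3 carries a different core, with a phenyl on a ring nitrogen; the difference between the two cores is not broken down here. In this assay compound 3 gives 7%, the lowest of the three, and the gaps to compound 1 and to compound 2 lie beyond the scatter.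

Compound 4, `CN1CCN(c2ccc(-c3cc4nn(-c5ccccc5)c(N)c4c(=O)[nH]3)cc2)CC1`, has not been measured. It carries the core of compound 3 and differs from it by 4-methylpiperazin-1-yl in place of methoxy on an aromatic carbon, the same change as from compound 1 to compound 2. Because a number 4 percentage points lower from compound 1 to compound 2 (within the scatter) was within the scatter, the step of a number 1 percentage points lower from compound 3 to compound 4 (within the scatter) is expected to be small as well. For compound 4 a value of 6% in this assay is estimated, with a range from 0% to 20%.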

Compound 4, a percentage reported as inhibition, at one concentration (the size of the read-out at that concentration, not a potency): 4%
The estimate for compound 4 lay 2 percentage points above the measured number, within the range that was stated.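

On the core of compound 3, 4-methylpiperazin-1-yl in place of methoxy gave a number 3 percentage points lower from compound 3 to compound 4 (within the scatter) in this assay and so made no readable difference. This matches the step on the core of compound 1, so in these two pairs the change carried from one core to the other with the same outcome: the same change on two cores in this assay, a number 4 percentage points lower (within the scatter) from compound 1 to compound 2 and a number 3 percentage points lower (within the scatter) from compound 3 to compound 4, 1 percentage points apart, within the scatter of two such steps

Within the data shown here, this covers only two cores and this one exchange, each read at a single concentration, and with compound 3 at 7% and compound 4 at 4% there is little room on the second core for a further fall to appear, so the agreement says nothing about potency or about other cores.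

The compounds shown leave open whether a smaller group on the ring nitrogen, such as methyl, would give numbers closer to those of the core of compound 1. They also leave open whether an open-chain amine or a carboxylic acid in place of methoxy would behave as 4-methylpiperazin-1-yl does.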